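The compounds below may be only part of what the source reports. "The series", "measured", "known", "first", "only" and "open" are said of these compounds alone.

Compound 1, `Cc1noc(-c2ccccc2NCC2=NCCN2)n1`: in a functional assay for activation of Alpha-1A adrenergic receptor (Homo sapiens), read by calcium flux (a higher number here means that more compound is needed for the effect, a lower number that less compound is needed), compound 1 gives 661 nM.
Compound 2, `c1ccc(-c2ccccc2NCC2=NCCN2)nc1`: in this assay compound 2 gives 6.76 nM.

Among the measured compounds shown here, of these two, compound 2 has the lower number, and its only neighbour is compound 1, with a 98-fold lower number from compound 1 to compound 2 (1.99 log units; beyond the scatter) between them. Compound 3, `c1cnc(-c2ccccc2NCC2=NCCN2)nc1`, differs from compound 2 in one place: pyrimidin-2-yl in place of pyridin-2-yl on an aromatic carbon. For the measured compounds named here, the one measured step that bears on this, from compound 1 to compound 2, was large, but it swapped a five-membered ring for a six-membered one; here the ring stays six-membered and aromatic and only gains a nitrogen. A small step is therefore expected in this assay, a 2.2-fold higher number from compound 2 to compound 3 (0.35 log units; beyond the scatter). Compound 3 is estimated at 15 nM, in the range 4 nM to 60 nM.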

Compound 3, half-maximal effective concentration: 10 nM
The estimate for compound 3 lay 1.5-fold (0.18 log units) above the measured number; low and high end bracket the measured number.
By their numbers in this assay, from the lowest: compounds 2 and 3 (each within the scatter of the next); then compound 1.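

In this assay, pyrimidin-2-yl and pyridin-2-yl cannot be told apart at this position, with a 1.5-fold higher number from compound 2 to compound 3 (0.17 log units; within the scatter). Pyrimidin-2-yl also stands well clear of 3-methyl-1,2,4-oxadiazol-5-yl, with a 66-fold lower number from compound 1 to compound 3 (1.82 log units; beyond the scatter), so the large earlier step now holds for two six-membered aromatic rings, not just one. No evidence on the cause of these steps is available.

Open, from the compounds shown here alone, is how a plain phenyl ring, with no ring nitrogen, would compare here. Also open, going by these compounds, is how a simple amine or a morpholine ring would compare at this position.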